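Adding a Hydroxymethyl to the Amide Chain of Compound 2

The compounds below may be only part of what the source reports. "The series", "measured", "known", "first", "only" and "open" are said of these compounds alone.

In a functional assay on PC-3 cells (Homo sapiens) for antiproliferative activity, read by MTT assay, with a stated time of 24 h (a lower number here means a stronger inhibitor, a higher number a weaker inhibitor), compound 2 `CCn1c(C(=O)NCCCO)ccc1C(CC)(CC)c1ccc(OCS(=O)(=O)c2ccccc2)c(C)c1` gives 11300 nM and stands at the top of the two numbers shown, although its only neighbour compound 1 `CCn1c(C(=O)N[C@H](CO)C(C)C)ccc1C(CC)(CC)c1ccc(OCS(=O)(=O)c2ccccc2)c(C)c1` with 7300 nM sits within the scatter of it, the difference being a 1.5-fold higher number from compound 1 to compound 2 (0.19 log units; within the scatter) on the amide nitrogen. Compound 3 `CCn1c(C(=O)N[C@@H](CO)CCO)ccc1C(CC)(CC)c1ccc(OCS(=O)(=O)c2ccccc2)c(C)c1` differs from compound 2 in one place hydroxymethyl in place of hydrogen on a saturated chain carbon bound to an amide-type nitrogen and a saturated chain carbon on the same chain. Going by the values given here, the single step that bears on this change is the one from compound 1 to compound 2, which stayed within the scatter, so no movement beyond the scatter is expected in this assay. Compound 3 is therefore estimated at 9500 nM with a range from 4500 nM to 20000 nM in this assay. That estimate means an expected step of a 1.2-fold lower number from compound 2 to compound 3 (0.08 log units; within the scatter) in this assay.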

Compound 3, half-maximal inhibitory concentration: 14100 nM
Beside the measured number, compound 3's estimate is 1.5-fold (0.17 log units) below it; measured number inside the range.
By their numbers in this assay, from the lowest: compounds 1, 2 and 3 (each within the scatter of the next).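

In this assay, hydroxymethyl in place of hydrogen on a saturated chain carbon bound to an amide-type nitrogen and a saturated chain carbon gives a 1.2-fold higher number from compound 2 to compound 3 (0.10 log units; within the scatter) and so leaves the number within the scatter. 3-Hydroxy-1-(hydroxymethyl)propyl in place of 1-(hydroxymethyl)-2-methylpropyl gives a 1.9-fold higher number from compound 1 to compound 3 (0.29 log units; within the scatter), which is also within the scatter, so this assay does not tell the three amide chains apart. No measurement at hand offers an explanation for this.

As far as these compounds go, whether an amine, a carboxylic acid or a longer chain on the amide nitrogen would move the number beyond the scatter remains open.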